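Sulfonyl variations on the piperazine amide tail

The compounds below may be only part of what the source reports. "The series", "measured", "known", "first", "only" and "open" are said of these compounds alone.

Measured so far in a functional assay on HCT-116 cells (Homo sapiens) for cytotoxicity, read by MTT assay, with a stated time of 48 h; a lower number here means a stronger inhibitor, a higher number a weaker inhibitor:
compound 1, `CCN(CC)c1ccc2cc(C(=O)c3ccc(N4CCN(C(=O)CN5CCNCC5)CC4)cc3)oc2c1`, 1870 nM
compound 2, `CCN(CC)c1ccc2cc(C(=O)c3ccc(N4CCN(C(=O)CN5CCN(S(=O)(=O)C6CC6)CC5)CC4)cc3)oc2c1`, for which only a limit is known, > 40000 nM
compound 3, `CCN(CC)c1ccc2cc(C(=O)c3ccc(N4CCN(C(=O)CN5CCN(S(=O)(=O)c6ccc(OC(F)(F)F)cc6)CC5)CC4)cc3)oc2c1`, 7680 nM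

Compound 3 stands at the higher of the two numbers actually resolved in this assay; compound 1 sits a good way below it, and the value of compound 2 is a limit of the assay and not a number (the limit of > 40000 nM in this assay, at which 1 of the 3 values shown sits).

Compound 4 is `CCN(CC)c1ccc2cc(C(=O)c3ccc(N4CCN(C(=O)CN5CCN(S(=O)(=O)c6ccc(C#N)cc6)CC5)CC4)cc3)oc2c1`. It differs from compound 3 in one place: cyano in place of trifluoromethoxy on an aromatic carbon.

The two measured steps both alter the sulfonyl substituent itself. Adding the sulfonyl gave an at least 21-fold higher number from compound 1 to compound 2 (1.33 log units; beyond the scatter), and exchanging cyclopropyl for 4-(trifluoromethoxy)phenyl gave an at least 5.2-fold lower number from compound 2 to compound 3 (0.71 log units; beyond the scatter). For the measured compounds named here, neither step swaps one substituent for another on the aromatic ring of an arylsulfonyl, so no measured step speaks directly to the change at hand. The ring and the sulfonyl link are kept in compound 4; only the group para to the large sulfonyl changes. The expectation is therefore a step in this assay that stays within the scatter, with no firm direction, and the estimate for compound 4 is 8000 nM (range 3000 nM to 25000 nM), which means an expected step of a 1.0-fold higher number from compound 3 to compound 4 (0.02 log units; within the scatter).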

Compound 4, half-maximal inhibitory concentration: 36400 nM
Compound 4: the middle estimate sits 4.6-fold (0.66 log units) below what was measured, and the stated range ends below it.
By their numbers in this assay, from the lowest: compound 1; then compound 3; then compound 4. At a limit, above all of these: compound 2.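

In this assay, for the compounds shown here, the group on the aromatic carbon para to a large group is not silent: with the ring and the sulfonyl link kept, cyano in place of trifluoromethoxy gives a 4.7-fold higher number from compound 3 to compound 4 (0.68 log units; beyond the scatter), whereas the earlier steps changed only the whole sulfonyl substituent or added it. Measured against the unsubstituted ring amine nitrogen, the (4-cyanophenyl)sulfonyl group gives a 19-fold higher number from compound 1 to compound 4 (1.29 log units; beyond the scatter), a large step that shows how much of the distance from the parent amine depends on this one ring substituent. With 4-cyanophenyl in place of cyclopropyl on the sulfonyl sulfur, the step reads an at least 1.0-fold lower number from compound 2 to compound 4 (0.04 log units; that floor lies within the scatter), which is only a floor and shows no resolved difference. The value of compound 2 is a limit and not a number: the limit of > 40000 nM in this assay, at which 1 of the 4 values shown sits.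

With a single pair of substituents on this ring, the compounds shown do not tell whether the difference between trifluoromethoxy and cyano extends to other groups at this place, such as a methoxy, an amine or a carboxylic acid. Where an unsubstituted phenyl would fall relative to compound 3 and compound 4 also stays open, as does whether a chlorine at this place would track either of them.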